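This account rests on a few compounds, and the source may have more. Where it says the series, first, only, none or still open, it means among the compounds named here.

Measured so far:
- compound 1 `O=C(c1cc(-c2cn[nH]c2)on1)N1CCC(Cc2ccc(Cl)cc2)CC1` — 29.2 mL/min/kg
- compound 2 `O=C(Nc1ccc2[nH]c(=O)oc2c1)C(=O)N1CCN(c2ccccc2)CC1` — "not determined" (no result reported)

In an ADME assay on the whole organism (Rattus norvegicus, strain Sprague-Dawley) for pharmacokinetics, using cassette dosing, at a dose of 0.5 mg/kg by the intravenous route (on this read-out lower numbers stand for slow clearance and higher numbers for fast clearance), compound 1 gives 29.2 mL/min/kg. In this assay, for the measured compounds named here, compound 2 gives "not determined" (no result reported) and stands on no single number; the run gave no result, so the series holds only the one value, from compound 1, and compound 1 shares no single-point relation with compound 2. Compound 3 `COc1ccc(N2CCN(C(=O)C(=O)Nc3ccc4[nH]c(=O)oc4c3)CC2)cc1F` is the next member. It differs from compound 2 by 3-fluoro-4-methoxyphenyl in place of phenyl on an amine nitrogen in a ring, a change on the amine nitrogen in the ring; the rest of the structure is kept. With no value for compound 2 and no step between measured compounds, the step in this assay from compound 2 to compound 3 cannot be sized or given a direction from the numbers shown. Going by the values given here, the estimate for compound 3 in this assay rests only on the one value from compound 1 and is 25 mL/min/kg, expected to fall between 8 mL/min/kg and 70 mL/min/kg.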

Compound 3, clearance: 101 mL/min/kg
Compound 3: the middle estimate sits 4.0-fold (0.61 log units) below what was measured; measured number outside the range, above it.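

No step can be read between compound 2 and compound 3, since in this assay compound 2 gives "not determined" (no result reported). From the compounds shown here alone, whether 3-fluoro-4-methoxyphenyl in place of phenyl changes clearance stays open. No evidence shown bears on the result of compound 3.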